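Hydrazide-Linked Ureas Against a Quinoline Anilinoalkyl Series

The source may report more compounds than this note shows. Statements on the series, on what has been measured and on what is new or still open speak of the compounds shown alone.

Measured so far in a functional assay on MOLT-4 cells (Homo sapiens) for inhibition, read by MTT assay, with a stated time of 72 h; on this read-out higher numbers stand for weaker inhibition and lower numbers for stronger inhibition:
compound 1, `COc1cc(NC(C)CCCNC(=O)NNC(=O)Nc2cccc(Cl)c2)c2ncccc2c1`: 93000 nM
compound 2, `COc1cc(NC(C)CCCNC(=O)NNC(=O)Nc2ccc(C(F)(F)F)cc2)c2ncccc2c1`: 24000 nM
compound 3, `COc1cc(NC(C)CCCNC(=O)Nc2cccc(F)c2)c2ncccc2c1`: 23000 nM

Compound 3 gives the lowest number among the three, but compound 2 sits within the usual scatter of it, so the two cannot be ordered; only compound 1 stands apart, with a number higher than both.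

Compound 4, `COc1cc(NC(C)CCCNC(=O)NNC(=O)Nc2ccc(Cl)cc2)c2ncccc2c1`, has not yet been measured. It differs from compound 3 in one place: ((4-chlorophenyl)carbamoyl)amino in place of 3-fluorophenyl on an amide-type nitrogen. For the measured compounds named here, two measured steps bear on this change. The step of a 4.0-fold lower number from compound 1 to compound 3 (0.61 log units; beyond the scatter) runs in the opposite direction to the present one, since it removes a ((3-chlorophenyl)carbamoyl)amino group and installs 3-fluorophenyl; read backwards it points to a higher number for compound 4. The step of a 3.9-fold lower number from compound 1 to compound 2 (0.59 log units; beyond the scatter), however, shows that a 4-substituted aryl urea on this chain gives a lower number than the 3-chlorophenyl one, and compound 4 carries a 4-chlorophenyl. Weighing the two, compound 4 is expected to land between compound 1 and compound 2, so that the estimated step is a 1.7-fold higher number from compound 3 to compound 4 (0.24 log units; within the scatter), an increase beyond the scatter.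

Accordingly, compound 4 is estimated at 40000 nM in this assay, within a range from 15000 nM to 110000 nM.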

Compound 4, half-maximal inhibitory concentration: 186000 nM
Beside the measured number, compound 4's estimate is 4.7-fold (0.67 log units) below it; measured number above the stated range.
By their numbers in this assay, from the lowest: compounds 3 and 2 (each within the scatter of the next); then compounds 1 and 4 (each within the scatter of the next).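

In this assay, the change of chloro in place of trifluoromethyl on an aromatic carbon gives a 7.8-fold higher number from compound 2 to compound 4 (0.89 log units; beyond the scatter), so the lower number seen earlier for the 4-(trifluoromethyl)phenyl urea does not carry over to every group on that ring position. The step of 4-chlorophenyl in place of 3-chlorophenyl on an amide-type nitrogen gives a 2.0-fold higher number from compound 1 to compound 4 (0.30 log units; within the scatter), so moving the chloro group does not separate these two compounds, and the substituent's identity made the clear difference in this small set. Replacing 3-fluorophenyl with ((4-chlorophenyl)carbamoyl)amino on an amide-type nitrogen gives an 8.1-fold higher number from compound 3 to compound 4 (0.91 log units; beyond the scatter), yet the longer urea group cannot be said to raise the number on its own, since compound 2 carries such a group and still lies within the scatter of compound 3.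

No measurement shown explains why chloro and trifluoromethyl part so widely on this ring. Going by these compounds, it remains open where a nitrile or a methoxy group on that aromatic carbon would fall relative to compound 2 and compound 4, and whether a longer chain would keep the same gap between them.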